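A few compounds are considered here, and "the series" means these few. Any claim that something is new, unique, unknown or untested is made for them only; others in the source may bear on it.

Among the compounds with values here, compound 2 `COc1ncc(-c2ccc3ncc(NCC4CCCCC4)c(OC)c3c2)cc1NS(=O)(=O)c1ccc(F)cc1F` gives 9000 nM in a functional assay on PC-3 cells (Homo sapiens) for antiproliferative activity, read by sulforhodamine B assay, with a stated time of 72 h (on this read-out higher numbers stand for weaker inhibition and lower numbers for stronger inhibition), and stands highest of the two numbers measured so far; its nearest neighbour is compound 1 `COc1ncc(-c2ccc3ncc(NCc4ccc(C(F)(F)F)cc4)c(OC)c3c2)cc1NS(=O)(=O)c1ccc(F)cc1F`, which in this assay gives 2880 nM. Within the data shown here, the single step between measured compounds, a 3.1-fold higher number from compound 1 to compound 2 (0.49 log units; beyond the scatter), goes with cyclohexyl in place of 4-(trifluoromethyl)phenyl on a saturated chain carbon bound to a nitrogen on an aromatic ring.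

Compound 3 `COc1ncc(-c2ccc3ncc(NC(=O)CN4CCCC(O)C4)c(OC)c3c2)cc1NS(=O)(=O)c1ccc(F)cc1F` is the next compound for this assay. It differs from compound 2 at the same nitrogen on the aromatic ring: ((3-hydroxypiperidin-1-yl)methyl)carbonyl in place of cyclohexylmethyl on a nitrogen on an aromatic ring. Among the measured compounds shown here, the group that leaves here is the one that entered in the only measured step, while the entering ((3-hydroxypiperidin-1-yl)methyl)carbonyl brings a double bond outside aromatic rings, a hydrogen-bond donor and three acceptors, none of which appear in either measured compound. For the measured compounds named here, no measured step covers a change of this kind; the step from compound 1 to compound 2 shows only that this position moves the number beyond the scatter, and gives no direction. The expected step is therefore a 1.3-fold lower number from compound 2 to compound 3 (0.11 log units; within the scatter), within the scatter, with a wide range. Compound 3 is estimated at 7000 nM in this assay, between 1500 nM and 30000 nM.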

Compound 3, half-maximal inhibitory concentration: 1340 nM
The estimate for compound 3 lay 5.2-fold (0.72 log units) above the measured number, outside the stated range (below it).
By their numbers in this assay, from the lowest: compound 3; then compound 1; then compound 2.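

In this assay, the nitrogen on the aromatic ring now shows a direction: placing ((3-hydroxypiperidin-1-yl)methyl)carbonyl there in place of cyclohexylmethyl goes with a 6.7-fold lower number from compound 2 to compound 3 (0.83 log units; beyond the scatter), and placing it there in place of 4-(trifluoromethyl)benzyl goes with a 2.1-fold lower number from compound 1 to compound 3 (0.33 log units; beyond the scatter). Both steps lie beyond the scatter, so the group with the carbonyl, the ring nitrogen and the hydroxyl gives the lowest number of the three, and the two groups without any hydrogen-bond donor or acceptor give the higher numbers. Nothing available bears on which feature of the entering group goes with this lower number.

As far as these compounds go, the entering group differs from both earlier groups in several features at once, so the share of the carbonyl, the ring nitrogen and the hydroxyl remains open. A plain acetyl group, a (piperidin-1-yl)methyl carbonyl without the hydroxyl, or a morpholine in place of the hydroxypiperidine on the same nitrogen would separate these contributions.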